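A few compounds are considered here, and "the series" means these few. Any claim that something is new, unique, unknown or untested is made for them only; others in the source may bear on it.

In an ADME assay on J774 cells (Mus musculus, strain BALB/c) for cytotoxicity, read by resazurin assay, with a stated time of 72 h (on this read-out lower numbers stand for higher toxicity in this test and higher numbers for lower toxicity in this test), compound 2 `COc1cc(C(=O)N/N=C(C)/C=N/Nc2ccc([N+](=O)[O-])cc2)ccc1O` gives > 100000 nM, which is a limit of the assay rather than a number. Compound 1 `CC(/C=N/Nc1ccc([N+](=O)[O-])cc1)=N\NC(=O)c1ccc(C(C)(C)C)cc1` likewise gives > 100000 nM, again a limit. Both measurements thus share (the limit of > 100000 nM in this assay, at which 2 of the 2 values shown sit). Compound 3 `COc1ccc(C(=O)N/N=C(C)/C=N/Nc2ccc([N+](=O)[O-])cc2)cc1` differs from compound 2 by 4-methoxyphenyl in place of 4-hydroxy-3-methoxyphenyl on a carbonyl carbon. Within the data shown here, no two measured compounds differ in a single place, so the size of this step is not known from data. Because both known values rest on (the limit of > 100000 nM in this assay, at which 2 of the 2 values shown sit), compound 3 is expected to remain there too. The expected step is a step that the limit leaves unreadable from compound 2 to compound 3, none beyond the usual scatter. For compound 3 the estimated value in this assay is 150000 nM, in a range from 60000 nM to 400000 nM.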

Compound 3, half-maximal cytotoxic concentration: > 100000 nM
Compound 3: only a limit was reported (the forecaster's own chance of this, stated with the estimate: 75%); the middle value lies beyond the limit too.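

No step can be read from compound 2 to compound 3 or from compound 1 to compound 3, because all three compounds rest at the same limit: (the limit of > 100000 nM in this assay, at which 3 of the 3 values shown sit). On these data alone, how far their true values differ in this assay stays open.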